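The source may hold more compounds than are shown below. What is called first, only, known or untested is meant among the compounds shown, and "the series" means these compounds.

Measured in a functional assay on HCT-116 cells (Homo sapiens) for inhibition, read by CCK-8 assay, with a stated time of 48 h; on this read-out higher numbers stand for weaker inhibition and lower numbers for stronger inhibition:
- Compound 1 `COc1cc(-c2ccnc3cc(-c4ccc(F)cc4)nn23)cc(OC)c1OC`: 5030 nM
- Compound 2 `COc1cc(-c2ccnc3cc(-c4ccc(C(F)(F)F)cc4)nn23)cc(OC)c1OC`: 1860 nM
- Compound 3 `COc1cc(-c2ccnc3cc(-c4ccc5cnn(C)c5c4)nn23)cc(OC)c1OC`: 2440 nM

Compound 3 stands within the scatter of compound 2 and clearly under compound 1, so only compound 1 separates from the others on these numbers. The next compound, compound 4 `COc1ccc(-c2cc3nccc(-c4cc(OC)c(OC)c(OC)c4)n3n2)cc1N`, keeps the shared core and exchanges one group: 3-amino-4-methoxyphenyl in place of 1-methyl-1H-indazol-6-yl on an aromatic carbon. In words, 3-amino-4-methoxyphenyl comes in place of 1-methyl-1H-indazol-6-yl on an aromatic carbon.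

Among the compounds with values here, three measured steps concern this same place. Two are modest and beyond the scatter, a 2.7-fold lower number from compound 1 to compound 2 (0.43 log units; beyond the scatter) and a 2.1-fold lower number from compound 1 to compound 3 (0.31 log units; beyond the scatter), while a 1.3-fold higher number from compound 2 to compound 3 (0.12 log units; within the scatter) stays within it. None of compounds 1 to 3 carries an amino group, so these steps bound the new one only loosely. A lower number in this assay is expected, by more than any step seen so far, though with little certainty about the size. The expected change is an 8.1-fold lower number from compound 3 to compound 4 (0.91 log units; beyond the scatter). Compound 4 is estimated at 300 nM, with an expected range of 25 nM to 2500 nM.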

Compound 4, half-maximal inhibitory concentration: 251 nM
For compound 4 the middle estimate is 1.2-fold (0.08 log units) above the measured one, and the stated range covers the measured number.
By their numbers in this assay, from the lowest: compound 4; then compounds 2 and 3 (each within the scatter of the next); then compound 1.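

In this assay, this place on an aromatic carbon of the five-membered aromatic ring proves able to carry much more of a change than compounds 1 to 3 showed, since the largest step among them was only modest (a 2.7-fold lower number from compound 1 to compound 2 (0.43 log units; beyond the scatter)). The 3-amino-4-methoxyphenyl group sets compound 4 apart from all three earlier compounds, with steps beyond the scatter against the indazolyl group (a 9.7-fold lower number from compound 3 to compound 4 (0.99 log units; beyond the scatter)), the 4-(trifluoromethyl)phenyl group (a 7.4-fold lower number from compound 2 to compound 4 (0.87 log units; beyond the scatter)) and the 4-fluorophenyl group (a 20-fold lower number from compound 1 to compound 4 (1.30 log units; beyond the scatter)), the last of them large. Of the four compounds, only compound 4 carries an amino group, but nothing available here accounts for the lower number.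

The amino and methoxy groups enter together, so the compounds shown leave open whether the step belongs to one of them or needs both, which a phenyl carrying only the 3-amino group or only the 4-methoxy group would separate. They also leave open whether the amino group itself matters, a question that a hydroxyl or an acetamide in its place would address.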